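A few compounds are considered here, and "the series" means these few. Any claim that something is new, unique, unknown or untested is made for them only; others in the source may bear on it.

Three compounds share one core and differ only in the aryl group carried on the five-membered ring. Compound 1 `Cc1ccc(-c2c(C)nn(-c3nc(-c4ccc(Cl)c(Cl)c4)c(SC(C)C)s3)c2C(=O)O)cc1` carries a 4-methylphenyl and in a functional assay on BJAB cells (Homo sapiens) for antiproliferative activity, with a stated time of 4 days (on this read-out higher numbers stand for an effect only at larger amounts of compound and lower numbers for an effect already at smaller amounts), compound 1 gives 3800 nM. Compound 2 `Cc1ccccc1-c1c(C)nn(-c2nc(-c3ccc(Cl)c(Cl)c3)c(SC(C)C)s2)c1C(=O)O` carries a 2-methylphenyl, and in this assay compound 2 gives 5500 nM, the second highest of the three numbers. Compound 3 `COc1ccccc1-c1c(C)nn(-c2nc(-c3ccc(Cl)c(Cl)c3)c(SC(C)C)s2)c1C(=O)O` carries a 2-methoxyphenyl, and compound 3 gives 14700 nM. The step of a 1.4-fold higher number from compound 1 to compound 2 (0.16 log units; within the scatter) shows that moving the methyl around the phenyl ring changed little, whereas a 2.7-fold higher number from compound 2 to compound 3 (0.43 log units; beyond the scatter) and a 3.9-fold higher number from compound 1 to compound 3 (0.59 log units; beyond the scatter) show a modest loss once methoxy replaces methyl.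

Compound 4 `Cc1cccc(-c2c(C)nn(-c3nc(-c4ccc(Cl)c(Cl)c4)c(SC(C)C)s3)c2C(=O)O)c1` has not been measured. It differs from compound 2 as follows: 3-methylphenyl in place of 2-methylphenyl on an aromatic carbon. The methyl stays a methyl, so the closest guide is the step from compound 1 to compound 2, which lay within the scatter, and the step of a 1.2-fold lower number from compound 2 to compound 4 (0.09 log units; within the scatter) is expected to stay within the scatter as well. Compound 4 is therefore estimated at 4500 nM, within a range of 2000 nM to 10000 nM.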

Compound 4, half-maximal effective concentration: 17000 nM
Beside the measured number, compound 4's estimate is 3.8-fold (0.58 log units) below it; measured number outside the range, above it.
By their numbers in this assay, from the lowest: compounds 1 and 2 (each within the scatter of the next); then compounds 3 and 4 (each within the scatter of the next).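

In this assay the place of the methyl on the phenyl ring turns out to matter, although the atoms stay the same: the change to 3-methylphenyl gives a 3.1-fold higher number from compound 2 to compound 4 (0.49 log units; beyond the scatter) and a 4.5-fold higher number from compound 1 to compound 4 (0.65 log units; beyond the scatter), so the small step between the 4-methylphenyl and the 2-methylphenyl does not hold for all three placements. The 3-methylphenyl, which carries no methoxy, also ends up level with the 2-methoxyphenyl, at a 1.2-fold higher number from compound 3 to compound 4 (0.06 log units; within the scatter), so a number in this range does not depend on a methoxy group. Nothing available here accounts for these differences.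

The compounds shown leave open whether a 3-methoxyphenyl or a 4-methoxyphenyl would follow the pattern of the matching methylphenyl. They also leave open how an amine or a chloro group would behave at each of these places on the phenyl ring.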